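A few compounds are considered here, and "the series" means these few. Any claim that something is new, unique, unknown or untested is made for them only; others in the source may bear on it.

Measured in a physicochemical assay for lipophilicity, read by HPLC, in phosphate buffer, measured as octanol-water partition, at pH 7.4, tested at 100 uM; on this read-out higher numbers stand for higher lipophilicity and lower numbers for lower lipophilicity:
Compound 1 `Cc1ccccc1-c1cccc(CNc2ccc(OCC(=O)O)c(F)c2)c1`: 2.41
Compound 2 `COc1ccccc1-c1cccc(CNc2ccc(OCC(=O)O)c(F)c2)c1`: "not determined" (no result reported)
Compound 3 `Cc1cc(O)ccc1-c1cccc(CNc2ccc(OCC(=O)O)c(F)c2)c1`: 1.85

For the measured compounds named here, compound 3 holds the lower of the two numbers available, with compound 1 the only neighbour to compare, since compound 2 offers no number. Compound 4 `Cc1cc(OCCO)ccc1-c1cccc(CNc2ccc(OCC(=O)O)c(F)c2)c1` differs from compound 3 in one place: 2-hydroxyethyl in place of hydrogen on an oxygen on an aromatic ring. In words, this is 2-hydroxyethyl in place of hydrogen on an oxygen on an aromatic ring, or hydroxy to 2-hydroxyethoxy.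

Going by the values given here, only one measured step bears on this change, and only indirectly: a number 0.56 log units lower from compound 1 to compound 3 (beyond the scatter). That modest step, hydroxy in place of hydrogen on an aromatic carbon, concerns the same hydroxy group that is now substituted. Among the compounds with values here, no measured step shows a substitution on such an oxygen, so the evidence is thin. Within the data shown here, the new chain still ends in a hydroxy group, so a step smaller than the one seen for compound 3 is expected in this assay, upward if anything and not beyond the scatter. The estimated change is a number 0.10 log units higher from compound 3 to compound 4 (within the scatter). For compound 4 the expected value is 1.95, with an estimated range of 1.6 to 2.3.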

Compound 4, distribution coefficient: 1.65
Beside the measured number, compound 4's estimate is 0.30 log units above it; the measured number falls inside the stated range.
By their numbers in this assay, from the lowest: compounds 4 and 3 (each within the scatter of the next); then compound 1.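

In this assay, 2-hydroxyethyl in place of hydrogen on an oxygen on an aromatic ring gives a number 0.20 log units lower from compound 3 to compound 4 (within the scatter) and so this read-out does not separate the two compounds. For the compounds shown here, this is the first measured substitution on that oxygen, and it shows that the added chain leaves the step within the scatter. Set against the parent without any oxygen there, the whole 2-hydroxyethoxy group gives a number 0.76 log units lower from compound 1 to compound 4 (beyond the scatter) and so stays beyond the scatter, as does a number 0.56 log units lower from compound 1 to compound 3 (beyond the scatter) for hydroxy alone. Nothing measured here accounts for these numbers. The compounds shown leave open whether an amine or a carboxylic acid in place of the 2-hydroxyethyl group, or a longer chain on the same oxygen, would give a step from compound 3 that lies beyond the scatter.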